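The source may hold more compounds than are shown below. What is called first, only, known or untested is meant among the compounds shown, and "the series" means these compounds.

Compound 1 `CCCOC(=O)C1=C(C)NC(=S)NC1c1ccco1` gives 1% in an assay on membranes from HeLa cells for displacement of a labelled ligand from adenosine receptor A3 (Homo sapiens), read by scintillation counting, with a stated time of 180 min, tested at 1 uM; on this read-out higher numbers stand for more inhibition at the one concentration tested (going by the name of the read-out) and lower numbers for less inhibition. Compound 2 `CC1=C(C(=O)OCC(C)C)C(c2ccco2)NC(=S)N1` carries methyl in place of hydrogen on a saturated chain carbon bound to two saturated chain carbons relative to compound 1, and in this assay compound 2 gives 10%, so that the step is a number 9 percentage points higher from compound 1 to compound 2 (within the scatter). Compound 3 `CCNC(=O)C1=C(C)NC(=O)NC1c1ccco1` gives 3% in this assay; how its core differs from that of compound 1 is not broken down here. Compound 4 `CC1=C(C(=O)NC(C)C)C(c2ccco2)NC(=O)N1` carries methyl in place of hydrogen on a saturated chain carbon bound to an amide-type nitrogen and a saturated chain carbon. This is the same kind of change as that made from compound 1 to compound 2, not the same change: in the earlier pair the carbon is bound to two saturated chain carbons, in the later pair to an amide-type nitrogen and a saturated chain carbon. Going by the values given here, because a number 9 percentage points higher from compound 1 to compound 2 (within the scatter) is the only measured instance of this kind of change and lies within the scatter, a similarly small step is expected, a number 2 percentage points higher from compound 3 to compound 4 (within the scatter). Compound 4 is therefore estimated at 5%, with a range from -5% to 15%.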

Compound 4, a percentage reported as inhibition, at one concentration (the size of the read-out at that concentration, not a potency): 4%
The estimate for compound 4 lay 1 percentage points above the measured number, within the range that was stated.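

In this assay the methyl in place of hydrogen gives a number 1 percentage points higher from compound 3 to compound 4 (within the scatter), and the two instances of this kind of change do not differ: the same change on two cores in this assay, a number 9 percentage points higher (within the scatter) from compound 1 to compound 2 and a number 1 percentage points higher (within the scatter) from compound 3 to compound 4, 8 percentage points apart, within the scatter of two such steps

On these two cores, then, the change stays within the scatter, and nothing marks its outcome as dependent on the core. This does not show that the change would carry over alike to a compound with a clear effect at the one concentration tested, since neither step rises beyond the scatter and the carbon carrying the methyl is bound differently in the two pairs.

The compounds shown leave open whether a longer chain, a benzyl group or an amine on this side chain would move the number beyond the scatter. Also open, on these data alone, is whether a carboxylic acid there would do so.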